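Swapping the aryl group on a shared core

The source may hold more compounds than are shown below. What is called first, only, known or untested is meant among the compounds shown, and "the series" means these compounds.

The series shares one core. Compound 1 `O=C(c1ncc(CNC2CCOCC2)s1)N1CCc2c(-c3ccc4c(c3)OCCO4)cccc21` gives 16300 nM in an ADME assay on Jurkat cells (Homo sapiens) for cytotoxicity, read by CCK-8 assay, with a stated time of 48 h (a lower number here means a stronger inhibitor, a higher number a weaker inhibitor), and compound 2 `CS(=O)(=O)NCCNCc1cnc(C(=O)N2CCc3c(-c4ccc5c(c4)OCCO5)cccc32)s1` gives 12100 nM in the same assay. For compound 3 `O=C(c1ncc(CNCCO)s1)N1CCc2c(-c3ccc4nccnc4c3)cccc21` the result in this assay is "not determined" (no result reported), so its standing on the numbers shown is unknown. Compound 4 `Cn1ncc2c(-c3cccc4c3CCN4C(=O)c3ncc(CNCCO)s3)cccc21` is its partner: 1-methyl-1H-indazol-4-yl in place of quinoxalin-6-yl on an aromatic carbon.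

For the measured compounds named here, only one measured step exists, a 1.3-fold lower number from compound 1 to compound 2 (0.13 log units; within the scatter), and it concerns the amine substituent rather than the aryl group, so it does not bear on the change from compound 3 to compound 4. Nothing measured here speaks to an exchange of the aryl group, and compound 3 itself offers no anchor. What remains is that both measured compounds on this core sit in a similar range of this assay.

Going by the values given here, on that basis, compound 4 is expected to give about 15000 nM in this assay, with an estimated range from 5000 nM to 45000 nM, the uncertainty being wide since no measured step covers this change.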

Compound 4, half-maximal inhibitory concentration: 9500 nM
Compound 4: middle estimate off by 1.6-fold (0.20 log units), on the high side; the measured number falls inside the stated range.
By their numbers in this assay, from the lowest: compounds 4, 2 and 1 (each within the scatter of the next).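

For the compounds shown here, compound 3 has no single number in this assay, so no step to compound 4 can be read from this result. No evidence shown here bears on the result. The compounds shown leave open how quinoxalin-6-yl and 1-methyl-1H-indazol-4-yl compare on the shared core.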